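The source may report more compounds than this note shows. Statements on the series, on what has been measured and on what is new or still open speak of the compounds shown alone.

Compound 2 `CCN(CC)CCNC(=O)c1ccc(C(CC)(CC)c2ccc(OCCC(O)(CC)CC)c(C)c2)n1CC` gives 2.3 nM in an assay on cells for agonist activity at vitamin D3 receptor (Homo sapiens), with a stated time of 96 h (a lower number here means that less compound is needed, a higher number that more compound is needed for the effect), the lowest of the three numbers recorded. Compound 1 `CCn1c(C(=O)NCCN(C)C)ccc1C(CC)(CC)c1ccc(OCCC(O)(CC)CC)c(C)c1` gives 82 nM in this assay, and compound 3 `CCn1c(C(=O)Nc2cccc(C(F)(F)F)c2)ccc1C(CC)(CC)c1ccc(OCCC(O)(CC)CC)c(C)c1` gives 5900 nM. Compound 4 `CCn1c(C(=O)NC(C)CO)ccc1C(CC)(CC)c1ccc(OCCC(O)(CC)CC)c(C)c1` differs from compound 2 in one place: 1-(hydroxymethyl)ethyl in place of 2-(diethylamino)ethyl on an amide-type nitrogen. For the measured compounds named here, two steps bear on this change. The step of a 36-fold lower number from compound 1 to compound 2 (1.55 log units; beyond the scatter) shows how much the larger amine chain was worth, and the step of a 2600-fold higher number from compound 2 to compound 3 (3.41 log units; beyond the scatter) shows the cost of removing the amine chain for an aromatic group. Compound 4 carries no amine yet remains a short chain. For compound 4 the expected step is a 220-fold higher number from compound 2 to compound 4 (2.34 log units; beyond the scatter), a large rise but smaller than the aromatic replacement produced. Compound 4 is therefore estimated at 500 nM, within 60 nM to 4000 nM.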

Compound 4, half-maximal effective concentration: 96 nM
Compound 4: the middle estimate sits 5.2-fold (0.72 log units) above what was measured; low and high end bracket the measured number.
By their numbers in this assay, from the lowest: compound 2; then compounds 1 and 4 (each within the scatter of the next); then compound 3.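

With a 1.2-fold higher number from compound 1 to compound 4 (0.07 log units; within the scatter), the 1-(hydroxymethyl)ethyl group on the amide-type nitrogen performs like the 2-(dimethylamino)ethyl group, so an amine on this chain is not needed to reach this level. Yet a 42-fold higher number from compound 2 to compound 4 (1.62 log units; beyond the scatter) leaves the 2-(diethylamino)ethyl group well ahead, while a 61-fold lower number from compound 3 to compound 4 (1.79 log units; beyond the scatter) places this short chain far ahead of 3-(trifluoromethyl)phenyl. No measurement offered here explains these gaps. Going by these compounds, whether a longer chain ending in a hydroxyl group, or a carboxylic acid, on this nitrogen would approach compound 2 at 2.3 nM stays open.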